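The compounds below may be only part of what the source reports. "The series", "measured", "known", "first", "only" and "open" are said of these compounds alone.

Compounds measured in a functional assay on HCT-116 cells (Homo sapiens) for cytotoxicity, read by MTT assay, with a stated time of 72 h; a lower number here means a stronger inhibitor, a higher number a weaker inhibitor:

Compound 1, `COc1ccc(Nc2nc3ccccc3nc2S(=O)(=O)c2ccc(C)cc2)cc1`, gives > 50000 nM, which is a limit of the assay and not a number.
Compound 2, `Cc1ccc(S(=O)(=O)c2nc3ccccc3nc2Nc2cccc(N)c2)cc1`, gives 2390 nM.
Compound 3, `Cc1ccc(S(=O)(=O)c2nc3ccccc3nc2Nc2ccc(C(F)(F)F)cc2)cc1`, gives 950 nM.

Compound 1 therefore stands at the upper limit of the measured set the limit of > 50000 nM in this assay, at which 1 of the 3 values shown sits: it is known only to be weaker than the highest concentration tested, and nothing more can be said about its place among the numbers. Compound 4, `COc1ccc(Nc2nc3ccccc3nc2S(=O)(=O)c2ccc(F)cc2)cc1`, differs from compound 1 in one place: fluoro in place of methyl on an aromatic carbon. The aryl ring carrying the sulfonyl group thus changes from 4-methylphenyl to 4-fluorophenyl, on an aromatic carbon of a six-membered aromatic ring of carbon only, para to a large group.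

Among the compounds with values here, none of the measured steps touches that ring. The steps of an at least 20-fold lower number from compound 1 to compound 2 (1.32 log units; beyond the scatter), an at least 52-fold lower number from compound 1 to compound 3 (1.72 log units; beyond the scatter) and a 2.5-fold lower number from compound 2 to compound 3 (0.40 log units; beyond the scatter) all concern the aryl group on the nitrogen, which is kept unchanged between compound 1 and compound 4. Those steps show that the set can move by large amounts, but they give no guide to an exchange of methyl for fluoro on the sulfonyl-bearing ring. With compound 1 itself sitting at the limit, the expected outcome is that compound 4 stays near the same place, so the step is estimated as a step that the limit leaves unreadable from compound 1 to compound 4. Compound 4 is accordingly expected at about 60000 nM, with a range from 15000 nM to 200000 nM, and it may well again be reported only as a limit.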

Compound 4, half-maximal inhibitory concentration: 3010 nM
Beside the measured number, compound 4's estimate is 20-fold (1.30 log units) above it; the measured number lies below the stated range.
By their numbers in this assay, from the lowest: compound 3; then compounds 2 and 4 (each within the scatter of the next). At a limit, above all of these: compound 1.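

In this assay, the ring carrying the sulfonyl group proves to be a place that matters: with the 4-methoxyphenyl group on the nitrogen kept, 4-fluorophenyl in place of 4-methylphenyl gives an at least 16-fold lower number from compound 1 to compound 4 (1.22 log units; beyond the scatter), a large step. The earlier steps had shown movement only through the aryl group on the nitrogen, whereas this one shows that fluoro in place of methyl, on an aromatic carbon para to a large group, is enough on its own to bring a measurable number out of the series' limit. The true size of the step remains unknown, because compound 1 is known only through a limit of the assay: the limit of > 50000 nM in this assay, at which 1 of the 4 values shown sits.

The compounds shown leave open whether the same exchange would have a comparable effect with the 3-aminophenyl group of compound 2 or the 4-(trifluoromethyl)phenyl group of compound 3 on the nitrogen. They also leave open how this place on the ring would respond to other groups, such as chloro, an amine or a carboxylic acid, and so whether fluoro itself is special there or methyl is simply poorly placed.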